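Bromo for methyl, carried from one core to another

The compounds below may be only part of what the source reports. "The series", "measured", "known", "first", "only" and "open" are said of these compounds alone.

Compound 1 `Cc1ccc(-c2cc3c(=N)sc(=S)[nH]c3n2-c2ccccc2)cc1` and compound 3 `Cc1ccc(-c2cc3c(=N)n(N)c(=S)[nH]c3n2-c2ccccc2)cc1` share most of their structure; the difference between the two cores is not broken down here. In a functional assay on the whole organism for inhibition, with Rattus norvegicus as the target, read by ELISA, with stated times of 30 min and 6 h, at a dose of 30 mg/kg by the oral route (on this read-out lower numbers stand for less inhibition and higher numbers for more inhibition at the one dose given (going by the name of the read-out)), compound 1 gives 0%, and compound 3 gives 0%, the two values lying within the scatter of each other. Compound 2 `N=c1sc(=S)[nH]c2c1cc(-c1ccc(Br)cc1)n2-c1ccccc1` differs from compound 1 by bromo in place of methyl on an aromatic carbon. In this assay compound 2 gives 44%, so that a number 44 percentage points higher from compound 1 to compound 2 (beyond the scatter). Compound 4 `N=c1c2cc(-c3ccc(Br)cc3)n(-c3ccccc3)c2[nH]c(=S)n1N` is not yet measured; it differs from compound 3 by bromo in place of methyl on an aromatic carbon, the same kind of change as between compound 1 and compound 2, at a place described in the same words, but on the core of compound 3 rather than that of compound 1. Among the compounds with values here, only one measured instance of this change exists, and it sits on a different core, so the transfer carries real uncertainty. Within the data shown here, the expected step from compound 3 to compound 4 is a number 35 percentage points higher from compound 3 to compound 4 (beyond the scatter), resting on a number 44 percentage points higher from compound 1 to compound 2 (beyond the scatter) as the sole precedent. Compound 4 is accordingly estimated at 35% in this assay, within a range from 10% to 60%.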

Compound 4, a percentage reported as inhibition, in the whole organism at one dose (the size of the read-out at that dose, not a potency): 33%
The estimate for compound 4 lay 2 percentage points above the measured number; the range from low to high includes it.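

In this assay the change of bromo for methyl also registers on the core of compound 3, with a number 33 percentage points higher from compound 3 to compound 4 (beyond the scatter). Set beside the earlier instance, the two steps agree: the same change on two cores in this assay, a number 44 percentage points higher (beyond the scatter) from compound 1 to compound 2 and a number 33 percentage points higher (beyond the scatter) from compound 3 to compound 4, 11 percentage points apart, within the scatter of two such steps. For these two cores, and at this one oral dose, the change from 4-methylphenyl to 4-bromophenyl therefore goes the same way, and the size of the step does not separate the cores, but two pairs do not show why the step arises, give no measure of potency and do not establish that it would carry to any further core.

The compounds shown leave open whether other groups at the same place on the aromatic ring, such as chloro, methoxy or a carboxylic acid, would follow bromo or methyl on either core. Also open, on these data alone, is whether the step survives when the unsubstituted phenyl group is replaced, for example by a longer chain or a group bearing an amine.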